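The source may hold more compounds than are shown below. What is called first, only, known or untested is meant among the compounds shown, and "the series" means these compounds.

Compound 1 `O=C(Nc1cccc(-c2oc3cc(-c4ccc(F)cc4)ccc3c(=O)c2O)c1)c1ccccc1F` gives 17400 nM in a functional assay on GTL 16 cells for antiproliferative activity against GTL 16 cell line (Homo sapiens), read by CCK-8 assay, with a stated time of 72 h; on this read-out lower numbers stand for stronger inhibition and higher numbers for weaker inhibition.
Compound 2 `O=C(Nc1cccc(-c2oc3cc(-c4ccc(F)cc4)ccc3c(=O)c2O)c1)c1ccc(F)cc1F` gives 9640 nM in this assay.

Of these two numbers, compound 2 has the lower one, yet the step of a 1.8-fold lower number from compound 1 to compound 2 (0.26 log units; within the scatter) lies within the scatter, so the two compounds cannot really be told apart. Compound 3 `COc1ccccc1C(=O)Nc1cccc(-c2oc3cc(-c4ccc(F)cc4)ccc3c(=O)c2O)c1` has not yet been measured. It differs from compound 2 by 2-methoxyphenyl in place of 2,4-difluorophenyl on a carbonyl carbon. Within the data shown here, the only measured step, a 1.8-fold lower number from compound 1 to compound 2 (0.26 log units; within the scatter), came from fluoro in place of hydrogen on an aromatic carbon and stayed within the scatter. The new change replaces the whole 2,4-difluorophenyl ring with a 2-methoxyphenyl ring, a larger alteration than anything measured here, so no direction can be read from the data, and no step beyond the scatter is expected in this assay. Compound 3 is therefore estimated at 12000 nM, within 4000 nM to 40000 nM, which means an expected step of a 1.2-fold higher number from compound 2 to compound 3 (0.10 log units; within the scatter).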

Compound 3, half-maximal inhibitory concentration: 6370 nM
For compound 3 the middle estimate is 1.9-fold (0.28 log units) above the measured one; low and high end bracket the measured number.
By their numbers in this assay, from the lowest: compounds 3, 2 and 1 (each within the scatter of the next, the first and the last beyond it).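

On a carbonyl carbon, 2-methoxyphenyl can take the place of 2,4-difluorophenyl with a 1.5-fold lower number from compound 2 to compound 3 (0.18 log units; within the scatter), so in this assay these two rings cannot be told apart, even though one carries a hydrogen-bond acceptor and the other none. Methoxy in place of fluoro on an aromatic carbon gives the first step in this series beyond the scatter, a 2.7-fold lower number from compound 1 to compound 3 (0.44 log units; beyond the scatter), though it is only a modest one. The data shown offer no measurement that could explain this step.

On these data alone, it remains open whether an amine or a carboxylic acid in place of the methoxy would move the number further in either direction. Also open, as far as these compounds go, is whether a longer chain, such as ethoxy, would keep the step seen with methoxy.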